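A few compounds are considered here, and "the series" means these few. Any claim that something is new, unique, unknown or untested is made for them only; others in the source may bear on it.

Compound 2 `CC1(c2ccc(S(N)(=O)=O)cc2)NC(=O)N(CC(=O)C2CC2)C1=O` carries the shared core with a (cyclopropylcarbonyl)methyl group. In an ADME assay on HepG2 cells (Homo sapiens) for cytotoxicity, read by CellTiter-Glo, with a stated time of 48 h (on this read-out lower numbers stand for stronger inhibition and higher numbers for weaker inhibition), compound 2 gives only a limit, > 100000 nM. Compound 1 `CC(=O)CN1C(=O)NC(C)(c2ccc(S(N)(=O)=O)cc2)C1=O` likewise gives only a limit in this assay, > 100000 nM. The step that the two limits leave unreadable from compound 1 to compound 2 therefore cannot be read, as both values sit at the limit of > 100000 nM in this assay, at which 2 of the 2 values shown sit. Compound 3 `CC1(c2ccc(S(N)(=O)=O)cc2)NC(=O)N(CC(=O)C2CCCCC2)C1=O` differs from compound 2 by cyclohexyl in place of cyclopropyl on a carbonyl carbon. Going by the values given here, no measured step has a readable size, so no change beyond the scatter is expected in this assay, and compound 3 is estimated at 120000 nM, between 30000 nM and 500000 nM, which means an expected step that the limit leaves unreadable from compound 2 to compound 3.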

Compound 3, half-maximal inhibitory concentration in the HepG2 assay: > 100000 nM
Compound 3 ended at the assay's limit; the forecaster's own chance of this, stated with the estimate: 80%; the middle value does not contradict the limit.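

In the HepG2 assay compound 3 gives only a limit (> 100000 nM). Compound 1 and compound 2 also give only limits, so no step among these compounds can be read. The compounds shown leave open whether in the HepG2 assay any group on this carbonyl carbon would give a readable value. In a physicochemical assay for lipophilicity, at pH 7.4 (a lower number here means a more polar compound, a higher number a more lipophilic compound), compound 2 gives 1.51 and compound 3 gives 3.62 as measured values.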